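Half-life of compound 3 after a charged addition

The source may report more compounds than this note shows. Statements on the series, on what has been measured and on what is new or still open speak of the compounds shown alone.

Compound 1 `CC(C)(O/N=C(\C(=O)N[C@@H]1C(=O)N(S(=O)(=O)O)[C@@H]1Cn1ccnn1)c1csc(N)n1)C(=O)O`: 257 h
Compound 2 `CC(C)(O/N=C(\C(=O)N[C@@H]1C(=O)N(S(=O)(=O)O)[C@@H]1CN1C[C@@H](CNC(=N)N)OC1=O)c1csc(N)n1)C(=O)O`: > 37 h (a limit)

Within the data shown here, in a physicochemical assay for metabolic stability, read by HPLC and mass spectrometry, in phosphate buffer, at 37 degrees C, at pH 7.4 (a lower number here means that the compound disappears faster, a higher number that the compound lasts longer), compound 1 gives 257 h, the only true number available, so it cannot yet be ranked against any other measured compound. Compound 2 reads > 37 h, which is a limit and not a number.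

Compound 3 `CC(C)(O/N=C(\C(=O)N[C@@H]1C(=O)N(S(=O)(=O)O)[C@@H]1Cn1cc(NC(=O)C[N+](C)(C)C)nn1)c1csc(N)n1)C(=O)O` keeps the core of compound 1 and differs from it by a group of 8 heavy atoms (5 carbon, 2 nitrogen, 1 oxygen; no ring) in place of a hydrogen atom, on an aromatic carbon. A group with net charge +1 takes the place of a hydrogen atom, on an aromatic carbon of the five-membered aromatic ring with 3 nitrogen.

Among the measured compounds shown here, the one measured step is a step that the limit leaves unreadable from compound 1 to compound 2. That step replaces the whole ring rather than adding to it, and it gives no size to carry over. The data therefore fix neither the size nor the direction of the change. With compound 1 at 257 h, a moderate shortening is expected, though this is held loosely, and no change beyond the scatter remains possible. The expected change is a 2.1-fold lower number from compound 1 to compound 3 (0.33 log units; beyond the scatter). The estimate for compound 3 is 120 h, with an expected range from 35 h to 300 h.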

Compound 3, half-life: > 37 h
Compound 3 ended at the assay's limit; the forecaster's own chance of this, stated with the estimate: 25%; the middle value does not contradict the limit.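

In this assay compound 3 gives > 37 h, which is a limit of the assay and not a number, so no new step can be read from compound 1 to compound 3. The compounds shown leave open how far, or in which direction, the group with net charge +1 moves the half-life of compound 1.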